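This account rests on a few compounds, and the source may have more. Where it says the series, first, only, none or still open, it means among the compounds named here.

Compound 1 `CC(=O)Nc1ccc(S(=O)(=O)NNc2ccccc2)cc1` gives > 10000 nM in an assay on HeLa cells for inhibition of Indoleamine 2,3-dioxygenase 1 (Homo sapiens), read by spectrophotometry, with a stated time of 24 h (on this read-out lower numbers stand for an effect already at smaller amounts and higher numbers for an effect only at larger amounts of compound), which is a limit of the assay rather than a number.
Compound 2 `CC(=O)Nc1ccc(S(=O)(=O)NNc2ccc(C)cc2)cc1` gives 1170 nM in this assay.
Compound 3 `CC(=O)Nc1ccc(S(=O)(=O)NNc2ccc(Br)cc2)cc1` gives 85 nM in this assay.

Compound 3 has the lowest of the two numbers in this assay; its nearest neighbour is compound 2, with a 14-fold lower number from compound 2 to compound 3 (1.14 log units; beyond the scatter). Compound 4 `O=C(O)c1ccc(S(=O)(=O)NNc2ccc(Br)cc2)cc1` is compound 3 with carboxy in place of acetamido on an aromatic carbon. Going by the values given here, the measured steps, an at least 8.5-fold lower number from compound 1 to compound 2 (0.93 log units; beyond the scatter) and an at least 110-fold lower number from compound 1 to compound 3 (2.07 log units; beyond the scatter), all alter a group on the other aromatic ring, so no measured step tests a change at the acetamido. With nothing comparable to lean on, only a moderate step toward a higher number, possibly within the scatter, is expected for this change in this assay. Compound 4 is therefore expected to give about 400 nM, within a range of 60 nM to 3000 nM, which would mean a 4.7-fold higher number from compound 3 to compound 4 (0.67 log units; beyond the scatter).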

Compound 4, half-maximal effective concentration: 172 nM
Compound 4: middle estimate off by 2.3-fold (0.37 log units), on the high side; the measured number falls inside the stated range.
By their numbers in this assay, from the lowest: compound 3; then compound 4; then compound 2. At a limit, above all of these: compound 1.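

Going by these compounds alone, every earlier step changed the other aromatic ring, so this is the first reading of what a change at the acetamido position does. Carboxy in place of acetamido gives a 2.0-fold higher number from compound 3 to compound 4 (0.31 log units; beyond the scatter) in this assay, a modest step that is real but much smaller than a 14-fold lower number from compound 2 to compound 3 (1.14 log units; beyond the scatter) on the other ring. So, for this one swap, the acetamido position moves the number far less than that bromo-for-methyl change does.

Going by these compounds, whether an amine or a methyl ester at this position would keep the number this low stays open. Nothing shown bears on why the number moved.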